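The source may report more compounds than this note shows. Statements on the series, on what has been measured and on what is new or still open speak of the compounds shown alone.

For the measured compounds named here, in a functional assay on HT-29 cells (Homo sapiens) for inhibition, with a stated time of 72 h (a lower number here means a stronger inhibitor, a higher number a weaker inhibitor), compound 1 `COc1ccc(S(=O)(=O)N2CCc3cccc(-c4ccc(N(C)C)cc4)c32)cc1` gives 467 nM, the lower of the two numbers so far. Compound 2 `COc1ccc(S(=O)(=O)N2CCc3cccc(-c4cc(OC)c(OC)c(OC)c4)c32)cc1` gives 5100 nM, and the gap between the two lies beyond the scatter. Compound 3 `COc1ccc(S(=O)(=O)N2CCc3cccc(-c4cccnc4)c32)cc1` remains unmeasured. It carries pyridin-3-yl in place of 4-(dimethylamino)phenyl on an aromatic carbon. Going by the values given here, the data hold no step between measured compounds, so the expectation rests only on these two values and the structural change. A weaker inhibitor is expected in this assay, with an estimated step of a 3.2-fold higher number from compound 1 to compound 3 (0.51 log units; beyond the scatter). For compound 3 the expected value is 1500 nM, within an estimated range of 300 nM to 8000 nM.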

Compound 3, half-maximal inhibitory concentration: 76.3 nM
Compound 3: middle estimate off by 20-fold (1.29 log units), on the high side; the measured number lies below the stated range.
By their numbers in this assay, from the lowest: compound 3; then compound 1; then compound 2.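

At this aromatic carbon of the shared core, the 4-(dimethylamino)phenyl group of compound 1 is not needed for activity in this assay. Pyridin-3-yl, with fewer heavy atoms, gives a 6.1-fold lower number from compound 1 to compound 3 (0.79 log units; beyond the scatter) and so makes compound 3 the stronger inhibitor of the pair. Nothing measured accounts for this gain.

The compounds shown do not separate the contribution of the ring nitrogen from that of losing the dimethylamino group. Plain phenyl and pyridin-4-yl at this position would address that question.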